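Fluoro in place of hydroxy on a tetrahydronaphthalene sulfonamide

A few compounds are considered here, and "the series" means these few. Any claim that something is new, unique, unknown or untested is made for them only; others in the source may bear on it.

Measured compounds:
compound 1, `O=S(=O)(Nc1cccc2c1CCCC2c1c[nH]cn1)C1CC1`, 2690 nM
compound 2, `CS(=O)(=O)Nc1ccc(O)c2c1CCCC2c1c[nH]cn1`, only a limit in this assay

Of the compounds shown here, two have been tested in an assay on isolated protein for binding affinity to Alpha-1D adrenergic receptor (Rattus norvegicus), read by radioligand binding; a lower number here means a stronger inhibitor, a higher number a weaker inhibitor. Compound 1, with the structure `O=S(=O)(Nc1cccc2c1CCCC2c1c[nH]cn1)C1CC1`, gives 2690 nM in this assay. Compound 2, with the structure `CS(=O)(=O)Nc1ccc(O)c2c1CCCC2c1c[nH]cn1`, gives < 10000 nM in this assay, and this is a limit of the assay rather than a measured number. Where compound 2 stands can therefore be said only roughly: its affinity is at or beyond (the limit of < 10000 nM in this assay, at which 1 of the 2 values shown sits), and no ordering against compound 1 can be drawn from it.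

Compound 3, with the structure `CS(=O)(=O)Nc1ccc(F)c2c1CCCC2c1c[nH]cn1`, has not yet been measured in this assay. It differs from compound 2 by fluoro in place of hydroxy on an aromatic carbon. Within the data shown here, no measured pair shows this exchange, so no measured step is available for the size of the change. Given that compound 2 is known only by a limit, the value of compound 3 is expected to fall around 3000 nM, within about 700 nM to 13000 nM, which would mean an estimated step that the limit leaves unreadable from compound 2 to compound 3 from compound 2 to compound 3.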

Compound 3, inhibition constant: 3020 nM
The estimate for compound 3 lay 1.0-fold (0.00 log units) below the measured number, and the stated range covers the measured number.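

No step from compound 2 to compound 3 can be read in this assay, because compound 2 is known only by a limit: the limit of < 10000 nM in this assay, at which 1 of the 3 values shown sits.

The compounds shown leave open how large the change is when hydroxy is exchanged for fluoro, and whether compound 2 or compound 3 binds more strongly.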